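The compounds below may be only part of what the source reports. "The series", "measured", "known", "first", "only" and "open" are said of these compounds alone.

Compound 1 `COc1ccc(-c2cc3ccccc3nc2C=O)cc1` carries a formyl group on its shared core. In a functional assay on NCI-H1299 cells (Homo sapiens) for antiproliferative activity, read by XTT assay, with a stated time of 72 h (on this read-out lower numbers stand for stronger inhibition and higher numbers for weaker inhibition), compound 1 gives > 10000 nM, which is a limit of the assay rather than a number, so compound 1 stands at the weak end of what has been measured. Compound 2 `COc1ccc(-c2cc3ccccc3nc2/C=C/C(=O)c2ccc(OC)cc2OC)cc1` and compound 3 `COc1ccc(-c2cc3ccccc3nc2/C=C/C(=O)c2cccs2)cc1` replace that formyl with a longer arm ending in an aromatic ketone. In this assay compound 2 gives 3770 nM, and compound 3 gives 720 nM. The step of an at least 13-fold lower number from compound 1 to compound 3 (1.14 log units; beyond the scatter) shows how much the arm bearing a thiophen-2-yl ketone helps, and the step of a 5.2-fold lower number from compound 2 to compound 3 (0.72 log units; beyond the scatter) shows the thiophene ring doing better than the 2,4-dimethoxyphenyl ring.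

Compound 4 `COc1ccc(-c2cc3ccccc3nc2/C=C/C(=O)c2ccsc2)cc1` has not yet been measured. It differs from compound 1 as follows: 2-((thiophen-3-yl)carbonyl)ethenyl in place of formyl on an aromatic carbon. Among the compounds with values here, both measured steps bear on this change, and the one from compound 1 to compound 3 is the closer match, so a large drop in the number is expected. The expected step is an at least 11-fold lower number from compound 1 to compound 4 (1.04 log units; beyond the scatter). Compound 4 is estimated at 900 nM, within a range from 300 nM to 2700 nM.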

Compound 4, half-maximal inhibitory concentration: 1220 nM
For compound 4 the middle estimate is 1.4-fold (0.13 log units) below the measured one; the measured number falls inside the stated range.
By their numbers in this assay, from the lowest: compounds 3 and 4 (each within the scatter of the next); then compound 2. At a limit, above all of these: compound 1.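

Replacing thiophen-2-yl with thiophen-3-yl on the carbonyl carbon gives a 1.7-fold higher number from compound 3 to compound 4 (0.23 log units; within the scatter), so the two thiophene compounds cannot be told apart in this assay. The arm ending in a thiophen-3-yl ketone also improves on formyl, with an at least 8.1-fold lower number from compound 1 to compound 4 (0.91 log units; beyond the scatter), which shows that the gain seen with compound 3 is not tied to thiophen-2-yl alone. In place of the 2,4-dimethoxyphenyl ring, thiophen-3-yl gives a 3.1-fold lower number from compound 2 to compound 4 (0.49 log units; beyond the scatter), so both thiophene compounds do better than compound 2.

Going by these compounds, the true size of the gain over formyl stays open because compound 1 stands at a limit of the assay: the limit of > 10000 nM in this assay, at which 1 of the 4 values shown sits. Also open, on these data alone, is whether an amine or a carboxylic acid in place of the thiophene ring on the carbonyl carbon would keep this level of activity.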